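This account rests on a few compounds, and the source may have more. Where it says the series, first, only, none or still open, it means among the compounds named here.

Measured compounds:
compound 1, `Brc1ccc(NCc2cn(-c3ccccc3)nc2-c2ccccc2)cc1`: > 100000 nM (a limit)
compound 2, `FC(F)(F)c1ccc(-c2nn(-c3ccccc3)cc2CNc2ccc(Br)cc2)cc1`: 28000 nM

In an ADME assay on BHK-21 cells (Mesocricetus auratus) for cytotoxicity, read by MTT assay, with a stated time of 72 h (a lower number here means that less compound is tolerated, a higher number that more compound is tolerated), compound 1 gives > 100000 nM, which is a limit of the assay and not a number. Compound 1 therefore stands at the limit of > 100000 nM in this assay, at which 1 of the 2 values shown sits. Compound 2 gives 28000 nM. For the measured compounds named here, the single measured step, an at least 3.5-fold lower number from compound 1 to compound 2 (0.55 log units; beyond the scatter), changes a different part of the molecule from the one considered here and bears on the present step only indirectly, showing that the series can move away from the limit. Compound 3 is `Clc1ccc(NCc2cn(-c3ccccc3)nc2-c2ccccc2)cc1`. Relative to compound 1 the change is chloro in place of bromo on an aromatic carbon. Going by the values given here, no measured step covers this exchange, so no step beyond the scatter is expected, and the step from compound 1 is estimated as a number no higher from compound 1 to compound 3 (the limit leaves the size open). Compound 3 is accordingly expected to give 100000 nM in this assay, within a range from 40000 nM to 200000 nM, and quite possibly reported again only as a limit.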

Compound 3, half-maximal cytotoxic concentration: > 100000 nM
Compound 3 ended at the assay's limit (the forecaster's own chance of this, stated with the estimate: 60%); the middle value sits exactly at the limit.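

Compound 1 and compound 3 both end at a limit and not at a number, so no step can be read for chloro in place of bromo: the limit of > 100000 nM in this assay, at which 2 of the 3 values shown sit. The compounds shown leave open how far either compound lies past that limit, and whether this exchange changes tolerance at all.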